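Sulfonyl aryl variation on the shared core: chloro to methoxy

The compounds below may be only part of what the source reports. "The series", "measured", "known", "first", "only" and "open" are said of these compounds alone.

Compound 1 `Cc1ccc(S(=O)(=O)c2cnc3ccc(Cl)cc3c2N2CCC(C)CC2)cc1F` gives 68% in an assay on isolated protein for displacement of a labelled ligand from metabotropic glutamate receptor 5 (Homo sapiens), with a stated time of 60 min, tested at 1 uM; a higher number here means more inhibition at the concentration tested (going by the name of the read-out), a lower number less inhibition. Compound 2 `COc1ccc(S(=O)(=O)c2cnc3ccc(Cl)cc3c2N2CCC(C)CC2)cc1Cl` gives 46% in this assay. Among the compounds with values here, the one measured step, a number 22 percentage points lower from compound 1 to compound 2 (beyond the scatter), comes with 3-chloro-4-methoxyphenyl in place of 3-fluoro-4-methylphenyl on a sulfonyl sulfur. On the two numbers in hand, compound 2 stands lowest; its nearest neighbour is compound 1, higher by a margin beyond the scatter.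

Compound 3 `COc1ccc(S(=O)(=O)c2cnc3ccc(Cl)cc3c2N2CCC(C)CC2)cc1OC` is not yet measured. It differs from compound 2 by methoxy in place of chloro on an aromatic carbon of a six-membered aromatic ring of carbon only.

Within the data shown here, the step from compound 1 to compound 2 is the only one touching the same ring, and it changes two groups at once, so it does not isolate the chloro-to-methoxy exchange; the series holds no direct precedent for it. The expectation is therefore a step of no clear direction, and the estimated change a number 6 percentage points lower from compound 2 to compound 3 (within the scatter) is set close to zero with a wide range. Compound 3 is estimated at 40%, between 18% and 62%.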

Compound 3, a percentage reported as inhibition, at one concentration (the size of the read-out at that concentration, not a potency): 61%
Compound 3: middle estimate off by 21 percentage points, on the low side, and the stated range covers the measured number.
By their numbers in this assay, from the lowest: compound 2; then compounds 3 and 1 (each within the scatter of the next).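

Within the data shown here, this is the only exchange confined to one group on this ring: with methoxy in place of chloro, ortho to a methoxy group, a number 15 percentage points higher from compound 2 to compound 3 (beyond the scatter) in this assay and so the read-out responds to the group held at this position. Set against the 3-fluoro-4-methylphenyl ring, the 3,4-dimethoxyphenyl ring gives a number 7 percentage points lower from compound 1 to compound 3 (within the scatter) and so the two aryl groups are not told apart here, while the 3-chloro-4-methoxyphenyl ring of compound 2 stands apart from both by steps beyond the scatter. Nothing measured on these compounds bears on why the exchange moves the number.

The compounds shown leave open how a hydroxyl, an ethoxy or an amino group would read at this same position, ortho to a methoxy group, and so whether the higher number belongs to methoxy specifically or merely to the loss of chloro. Also open, from the compounds shown here alone, is whether the chloro-to-methoxy exchange reads the same when the other group on this ring is methyl rather than methoxy.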